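The source may hold more compounds than are shown below. What is called first, only, known or untested is meant among the compounds shown, and "the series" means these compounds.

- Compound 1 `CC(=O)N1N=C(c2ccc3ccccc3c2)OC1c1ccccc1`: 2.57 ug/mL
- Compound 2 `CC(=O)N1N=C(c2ccc3ccccc3c2)OC1c1ccc(C)cc1`: 3.85 ug/mL

In a functional assay on B16-F10 cells (Mus musculus) for antiproliferative activity, read by MTT assay, with a stated time of 48 h (a higher number here means a weaker inhibitor, a lower number a stronger inhibitor), compound 2 at 3.85 ug/mL stands within the scatter of compound 1 at 2.57 ug/mL. Compound 3 `CC(=O)N1N=C(c2ccc3ccccc3c2)OC1c1ccsc1` carries thiophen-3-yl in place of 4-methylphenyl on a saturated ring carbon. Going by the values given here, only one measured step bears on this change, a 1.5-fold higher number from compound 1 to compound 2 (0.18 log units; within the scatter), and it concerns a methyl on the same aromatic substituent. Among the compounds with values here, no measured compound carries a thiophene, so this evidence is indirect, and no shift beyond the scatter is expected in this assay. The expected change is a 1.3-fold lower number from compound 2 to compound 3 (0.11 log units; within the scatter). For compound 3, the estimated value is 3 ug/mL, with an expected range of 1.3 ug/mL to 7 ug/mL.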

Compound 3, half-maximal inhibitory concentration: 8.56 ug/mL
Compound 3: the middle estimate sits 2.9-fold (0.46 log units) below what was measured; the whole stated range lies below it.
By their numbers in this assay, from the lowest: compounds 1 and 2 (each within the scatter of the next); then compound 3.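

In this assay, replacing the aromatic group on the saturated ring carbon now moves the number beyond the scatter: the change gives a 2.2-fold higher number from compound 2 to compound 3 (0.35 log units; beyond the scatter) and, against the unsubstituted phenyl, a 3.3-fold higher number from compound 1 to compound 3 (0.52 log units; beyond the scatter) as well. This position therefore responds to the identity of its aromatic group, which the methyl step alone did not show. Nothing measured here accounts for the shift. The compounds shown leave open whether the higher number follows the sulfur or the five-membered aromatic ring. They also leave open how a furan-2-yl group or an aminophenyl group would read here.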